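Swapping a Nitrophenyl for a Methylfuran on the Core

The source may report more compounds than this note shows. Statements on the series, on what has been measured and on what is new or still open speak of the compounds shown alone.

Compound 1 `Cc1ccc(C2C(C#N)=C(N)N(c3ccc(S(N)(=O)=O)cc3)C3=C2C(=O)CCC3)cc1`: 100%
Compound 2 `COc1ccccc1C1C(C#N)=C(N)N(c2ccc(S(N)(=O)=O)cc2)C2=C1C(=O)CCC2`: 0%
Compound 3 `N#CC1=C(N)N(c2ccc(S(N)(=O)=O)cc2)C2=C(C(=O)CCC2)C1c1ccc([N+](=O)[O-])cc1`: 100%

In a functional assay on Ehrlich cells (Mus musculus) for antiproliferative activity, read by trypan blue exclusion, with a stated time of 2 h, tested at 100 ug/mL (a lower number here means a weaker effect, a higher number a stronger effect of the compound at the concentration tested), compound 3 stands level with compound 1 at the digits shown, the two together at the top of three numbers; the only gap beyond the scatter appears in a number 100 percentage points higher from compound 2 to compound 3 (beyond the scatter). Compound 4 `Cc1ccoc1C1C(C#N)=C(N)N(c2ccc(S(N)(=O)=O)cc2)C2=C1C(=O)CCC2` differs from compound 3 at one place: 3-methylfuran-2-yl in place of 4-nitrophenyl on a saturated ring carbon. Two measured steps alter the group on that same saturated ring carbon, and both were large: a number 100 percentage points lower from compound 1 to compound 2 (beyond the scatter) and a number 100 percentage points higher from compound 2 to compound 3 (beyond the scatter). Because a number 100 percentage points lower from compound 1 to compound 2 (beyond the scatter) shows that a change at this position can erase the effect entirely, and no five-membered ring has been tested there, the direction for compound 4 is uncertain. Compound 4 is expected to give 60%, within 5% to 100%. The expected step is therefore a number 40 percentage points lower from compound 3 to compound 4 (beyond the scatter).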

Compound 4, a percentage reported as activity, at one concentration (the size of the read-out at that concentration, not a potency): 45%
For compound 4 the middle estimate is 15 percentage points above the measured one; low and high end bracket the measured number.
By their numbers in this assay, from the lowest: compound 2; then compound 4; then compounds 1 and 3 (each within the scatter of the next).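

In this assay the 3-methylfuran-2-yl group gives a number 55 percentage points lower from compound 3 to compound 4 (beyond the scatter) and a number 55 percentage points lower from compound 1 to compound 4 (beyond the scatter) but also a number 45 percentage points higher from compound 2 to compound 4 (beyond the scatter) and so lands between the earlier results. This saturated ring carbon therefore allows a partial effect, not only all or none, and a five-membered aromatic ring can retain some of the activity. Nothing available explains these differences. The compounds shown leave open whether a group with no aromatic ring, such as a cyclohexyl ring or a propyl chain, retains any effect at this carbon.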